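Hydroxy to chloro on the aryl ring of a piperidinone amide

The source may report more compounds than this note shows. Statements on the series, on what has been measured and on what is new or still open speak of the compounds shown alone.

Compound 1 `CC1C(=O)CC(c2ccc(Cl)cc2)N(C(=O)CCl)C1c1ccc(O)cc1`: 39.7%
Compound 2 `CC1C(=O)CC(c2ccc(F)cc2)N(C(=O)CN2CCN(C)CC2)C1c1ccc(Cl)cc1`: 65.5%
Compound 3 `CC1C(=O)CC(c2ccc(F)cc2)N(C(=O)CCl)C1c1ccc(O)cc1`: 51.2%

In a functional assay on the whole organism for inhibition, with Mus musculus as the target, in the writhing test, with a stated time of 1 h, at a dose of 60 mg/kg by the oral route (on this read-out lower numbers stand for less inhibition and higher numbers for more inhibition at the one dose given (going by the name of the read-out)), compound 3 stands second highest of the three, with compound 1 beyond the scatter below it and compound 2 beyond the scatter above it. Compound 4 `CC1C(=O)CC(c2ccc(F)cc2)N(C(=O)CCl)C1c1ccc(Cl)cc1` differs from compound 3 by chloro in place of hydroxy on an aromatic carbon. Among the compounds with values here, the only measured step, a number 11.5 percentage points higher from compound 1 to compound 3 (beyond the scatter), concerns a different ring and a different pair of groups, so it does not bear directly on this change. Within the data shown here, compound 2 carries the same chlorophenyl group as compound 4 but a different amide, so its value shows only that such compounds can reach that level. Among the measured compounds shown here, with no step of this kind measured, compound 4 is expected to stay near compound 3, with a number 0.8 percentage points higher from compound 3 to compound 4 (within the scatter) taken as no change beyond the scatter; the estimate for compound 4 is 52%, between 32% and 72%.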

Compound 4, a percentage reported as inhibition, in the whole organism at one dose (the size of the read-out at that dose, not a potency): 57.6%
For compound 4 the middle estimate is 5.6 percentage points below the measured one; low and high end bracket the measured number.
By their numbers in this assay, from the lowest: compound 1; then compounds 3, 4 and 2 (each within the scatter of the next, the first and the last beyond it).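

On an aromatic carbon para to a large group, 4-chlorophenyl in place of 4-hydroxyphenyl gives a number 6.4 percentage points higher from compound 3 to compound 4 (within the scatter) and shows that the read-out holds without the hydroxy. With 4-chlorophenyl present, chloro in place of 4-methylpiperazin-1-yl on the saturated chain carbon gives a number 7.9 percentage points lower from compound 2 to compound 4 (within the scatter) and so the piperazine is not needed to reach this level. Nothing given here explains either step. Going by these compounds, it remains open whether a methoxy group or an amine at the same aromatic position would hold the read-out, and whether a morpholine would do so on the chain.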